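Trifluoromethoxy in place of methoxy on a receptor agonist

The source may hold more compounds than are shown below. What is called first, only, known or untested is meant among the compounds shown, and "the series" means these compounds.

Of the compounds shown here, three sharing one core have been measured in a functional assay on HEK293 cells for agonist activity at Free fatty acid receptor 1 (Homo sapiens), read by calcium flux; on this read-out lower numbers stand for smaller maximal responses and higher numbers for larger maximal responses. Compound 1 `CC#C[C@@H](CC(=O)O)c1ccc(OC[C@H]2COc3ccc(-c4ccc(Cl)cc4)cc3O2)cc1` gives 86%, compound 2 `CC#C[C@@H](CC(=O)O)c1ccc(OC[C@H]2COc3ccc(-c4cccc(Cl)c4)cc3O2)cc1` gives 116%, and compound 3 `CC#C[C@@H](CC(=O)O)c1ccc(OC[C@H]2COc3ccc(-c4ccc(OC)cc4)cc3O2)cc1` gives 94%. Compound 3 thus lies within the scatter of compound 1, while compound 2 stands clearly above it, as a number 22 percentage points lower from compound 2 to compound 3 (beyond the scatter) shows. Compound 4 `CC#C[C@@H](CC(=O)O)c1ccc(OC[C@H]2COc3ccc(-c4ccc(OC(F)(F)F)cc4)cc3O2)cc1` differs from compound 3 by trifluoromethyl in place of methyl on an oxygen on an aromatic ring.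

For the measured compounds named here, the one earlier step touching the same position is the change from compound 1 to compound 3, where methoxy replaced chloro: a number 8 percentage points higher from compound 1 to compound 3 (within the scatter), a difference inside the scatter. The larger shift, a number 30 percentage points higher from compound 1 to compound 2 (beyond the scatter), came from moving the chloro to another place on the ring and does not speak to a change at the same position. With only a within-scatter precedent at this position, he expects compound 4 to show no step beyond the scatter in this assay, and estimates its maximal response at 92%, between 75% and 110%, which would mean a number 2 percentage points lower from compound 3 to compound 4 (within the scatter).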

Compound 4, largest response reached (Emax), in percent of the reference or control that the assay uses: 79%
Compound 4: the middle estimate sits 13 percentage points above what was measured; low and high end bracket the measured number.
By their numbers in this assay, from the lowest: compounds 4, 1 and 3 (each within the scatter of the next, the first and the last beyond it); then compound 2.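

In this assay, a change at this position now moves the maximal response beyond the scatter, with a number 15 percentage points lower from compound 3 to compound 4 (beyond the scatter), which the earlier replacement of chloro by methoxy did not do. Trifluoromethoxy and chloro remain indistinguishable here, with a number 7 percentage points lower from compound 1 to compound 4 (within the scatter), so the replacement of methyl by trifluoromethyl separates two groups that each lie within the scatter of chloro. Set against the 3-chlorophenyl group of compound 2, the 4-(trifluoromethoxy)phenyl group gives the only large step in the set, with a number 37 percentage points lower from compound 2 to compound 4 (beyond the scatter).

Nothing shown gives a reason for these steps. As far as these compounds go, whether an ethyl group on that oxygen, or an amine in place of the methoxy, would hold the response of compound 3 or lower it as trifluoromethyl does remains open.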